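Replacing methyl(1,3-oxazol-2-yl)amino on the shared core

The source may report more compounds than this note shows. Statements on the series, on what has been measured and on what is new or still open speak of the compounds shown alone.

Measured so far in an ADME assay on microsomes from liver (Homo sapiens) for metabolic stability, read by LC-MS, using NADPH, with stated times of 5 min and 30 min, tested at 1 uM (on this read-out higher numbers stand for fast clearance and lower numbers for slow clearance), are three compounds:
compound 1 `CN(c1ncco1)c1cnc(NCc2c(F)ccc3c2CCO3)n2cnnc12` gives 11 mL.min-1.g-1 in this series
compound 2 `CN(C)Cc1ccc(C(=O)Nc2cnc(NCc3c(F)ccc4c3CCO4)n3cnnc23)cc1` gives 13 mL.min-1.g-1 in this series
compound 3 `Cc1ncc(-c2cnc(NCc3c(F)ccc4c3CCO4)c3cn[nH]c(=O)c23)n1C` gives 10 mL.min-1.g-1 in this series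

Compound 1 lies within the usual scatter of both compound 2 and compound 3, so the three values cannot be ranked. Compound 4 `CC1(C)CC(=O)N(c2cnc(NCc3c(F)ccc4c3CCO4)n3cnnc23)C1` keeps the core of compound 1 and carries 4,4-dimethyl-2-oxopyrrolidin-1-yl in place of methyl(1,3-oxazol-2-yl)amino on an aromatic carbon, a change counted as 4,4-dimethyl-2-oxopyrrolidin-1-yl in place of methyl(1,3-oxazol-2-yl)amino on an aromatic carbon and not yet measured. Among the measured compounds shown here, no measured pair in this small set isolates a single change, so the data offer no direct guide. The only indirect support is that compound 2, with a different group on the same core, gives 13 mL.min-1.g-1 in this assay and stays within the scatter of compound 1. A small rise is expected, with the estimated step of a 1.3-fold higher number from compound 1 to compound 4 (0.10 log units; within the scatter) remaining within the scatter. The estimate for compound 4 is 14 mL.min-1.g-1 in this assay, with an expected range from 7 mL.min-1.g-1 to 26 mL.min-1.g-1 for repeated measurements.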

Compound 4, intrinsic clearance in microsomes: 16 mL.min-1.g-1
Compound 4: the middle estimate sits 1.1-fold (0.06 log units) below what was measured, and the stated range covers the measured number.
By their numbers in this assay, from the lowest: compounds 3, 1, 2 and 4 (each within the scatter of the next).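

In this assay, the exchange of methyl(1,3-oxazol-2-yl)amino for 4,4-dimethyl-2-oxopyrrolidin-1-yl on the aromatic carbon para to a large group gives a 1.5-fold higher number from compound 1 to compound 4 (0.16 log units; within the scatter). Among the compounds shown here, this is the first pair that differs in one place only, and it shows that this position can go from a five-membered aromatic ring with 2 hetero atoms to a five-membered non-aromatic ring with 1 hetero atom without a step beyond the scatter on this read-out. No available measurement bears on this result.

Going by these compounds, whether the unsubstituted 2-oxopyrrolidin-1-yl would give a number within the scatter of compound 4 remains open. Also open, on these data alone, is whether a primary amine or a carboxylic acid at this position would give a step beyond the scatter from compound 1.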